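Benzyloxy to propoxy: expected cytotoxicity of compound 4

This account rests on a few compounds, and the source may have more. Where it says the series, first, only, none or still open, it means among the compounds named here.

Compound 1 `Nc1nc(OCc2ccccc2)c2ncn(/C=C3/CC3(CO)CO)c2n1` carries a benzyloxy group on the shared core. In an ADME assay on MOLT-3 cells (Homo sapiens) for cytotoxicity, with a stated time of 7 days (on this read-out lower numbers stand for higher toxicity in this test and higher numbers for lower toxicity in this test), compound 1 gives > 20000 nM, which is a limit of the assay and not a number. Two further members of the series were also entered in this assay: compound 2 `CC(C)Nc1nc(N)nc2c1ncn2/C=C1/CC1(CO)CO` has "not determined" (no result reported), and compound 3 `Nc1nc(NC2CCCCC2)c2ncn(/C=C3/CC3(CO)CO)c2n1` has "not determined" (no result reported). Compound 1 therefore stands as the only one of the three with any reading, and that reading is the limit of > 20000 nM in this assay, at which 1 of the 3 values shown sits.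

Compound 4 `CCCOc1nc(N)nc2c1ncn2/C=C1/CC1(CO)CO` has not been measured in this assay. It differs from compound 1 in a single place (ethyl in place of phenyl on a saturated chain carbon bound to an oxygen on an aromatic ring). Within the data shown here, there is no measured pair in the set that would show how such a change moves the read-out, so the expectation rests on compound 1 alone. Since compound 1 is recorded only as the limit of > 20000 nM in this assay, at which 1 of the 3 values shown sits, compound 4 is expected to give a result within the scatter of that limit, with the step from compound 1 to compound 4 estimated as a number no higher from compound 1 to compound 4 (the limit leaves the size open), that is, no step beyond the scatter in either direction. For compound 4 the estimate in this assay is 20000 nM, expected to lie between 8000 nM and 50000 nM, most likely reported again as a limit.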

Compound 4, half-maximal cytotoxic concentration: > 20000 nM
Compound 4 ended at the assay's limit; the forecaster's own chance of this, stated with the estimate: 80%; the middle value lies on the limit itself.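

Compound 1 and compound 4 both stand at a limit of this assay and not at a number, so no step between them can be read: the limit of > 20000 nM in this assay, at which 2 of the 4 values shown sit.

The compounds shown leave open whether benzyloxy to propoxy changes the half-maximal cytotoxic concentration at all, and where that concentration lies for either compound.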